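Thioether chain variation on a shared core: compound 3 outlook

This account rests on a few compounds, and the source may have more. Where it says the series, first, only, none or still open, it means among the compounds named here.

Measured so far:
compound 1 `CCSc1nc(Nc2cccc(OC)c2)c2ccncc2n1` gives 590 nM in a functional assay on MGC-803 cells (Homo sapiens) for inhibition, read by MTT assay, with a stated time of 72 h; a lower number here means a stronger inhibitor, a higher number a weaker inhibitor
compound 2 `CCCSc1nc(Nc2cccc(OC)c2)c2ccncc2n1` gives 1950 nM in this assay

Compound 2 stands highest of the two numbers shown; compound 1 lies nearest, and the step of a 3.3-fold higher number from compound 1 to compound 2 (0.52 log units; beyond the scatter) separates them, which means a modest loss on extending the chain from the sulfur. Compound 3 `COc1cccc(Nc2nc(SCC3CC3)nc3cnccc23)c1` takes the next step: cyclopropyl in place of ethyl on a saturated chain carbon bound to a sulfur. Among the compounds with values here, only the step from compound 1 to compound 2 bears on it, and it pointed to a weaker number with more chain carbon. A further modest loss, or none, is therefore expected, giving a 1.3-fold higher number from compound 2 to compound 3 (0.12 log units; within the scatter). Compound 3 is estimated at 2600 nM, within 900 nM to 7500 nM.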

Compound 3, half-maximal inhibitory concentration: 1340 nM
The estimate for compound 3 lay 1.9-fold (0.29 log units) above the measured number; the range from low to high includes it.
By their numbers in this assay, from the lowest: compound 1; then compounds 3 and 2 (each within the scatter of the next).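

In this assay, cyclopropyl in place of ethyl on a saturated chain carbon bound to a sulfur gives a 1.5-fold lower number from compound 2 to compound 3 (0.16 log units; within the scatter) and so stays within the scatter: propyl and cyclopropylmethyl cannot be told apart here. The ring does not recover what compound 1 holds, with a 2.3-fold higher number from compound 1 to compound 3 (0.36 log units; beyond the scatter) still beyond the scatter. No measurement shown offers a reason for either step.

From the compounds shown here alone, a hydroxyl, an amine or a longer chain at this chain carbon remains open. So does whether the number for compound 1 can be improved on at this position.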